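The compounds below may be only part of what the source reports. "The series", "measured", "known", "first", "only" and "open" are said of these compounds alone.

Measured in an ADME assay on 2209-23 cells (Homo sapiens) for cytotoxicity, read by WST assay and thymidine incorporation; a higher number here means that more compound is tolerated, a lower number that less compound is tolerated:
compound 1 `CC(C)(C)[C@H]1C(O)=C(C2=C(C#N)S(=O)(=O)c3cc(NS(C)(=O)=O)ccc3N2)C(=O)N1Cc1ccc(F)cc1` gives > 50000 nM
compound 2 `CC(C)(C)[C@H]1C(O)=C(C2=CS(=O)(=O)c3cc([N+](=O)[O-])ccc3N2)C(=O)N1Cc1ccc(F)cc1` gives > 50000 nM
compound 3 `CC(C)(C)[C@H]1C(O)=C(C2=C(C(N)=O)S(=O)(=O)c3cc(NS(C)(=O)=O)ccc3N2)C(=O)N1Cc1ccc(F)cc1` gives > 50000 nM

Each of these three values is a limit of this assay and not a number. The whole set therefore stands at one point: the limit of > 50000 nM in this assay, at which 3 of the 3 values shown sit. Compound 3 thus sits at the limit, and the two further values shown sit at the same limit, so nothing in this assay separates compound 3 from compound 1 or compound 2. Going by the values given here, the only step among the measured compounds that changes one place, a step that the two limits leave unreadable from compound 1 to compound 3, runs from one limit to another, and its size cannot be read.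

Compound 4 `CC(C)(C)[C@H]1C(O)=C(C2=CS(=O)(=O)c3cc(NS(C)(=O)=O)ccc3N2)C(=O)N1Cc1ccc(F)cc1` differs from compound 3 in one place: hydrogen in place of carbamoyl on a double-bonded ring carbon. Among the compounds with values here, the single measured step that bears on this position is the one from compound 1 to compound 3, and since that step is unreadable, it offers no size to carry over. What remains is that compound 1, compound 2 and compound 3 all sit at the limit in this assay. On that ground the step of a number no higher from compound 3 to compound 4 (the limit leaves the size open) is expected to be none beyond the scatter. Compound 4 is accordingly estimated at 50000 nM, within a range from 20000 nM to 120000 nM, most likely reported as a limit once more.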

Compound 4, half-maximal cytotoxic concentration: > 50000 nM
Compound 4: a limit, no number; the forecaster's own chance of this, stated with the estimate: 85%; the middle value sits exactly at the limit.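

In this assay compound 4 gives > 50000 nM, which is a limit and not a number. Its steps from compound 1, compound 2 and compound 3 cannot be read, and all four compounds stand together: the limit of > 50000 nM in this assay, at which 4 of the 4 values shown sit.

The compounds shown leave open what concentration of any of them ends tolerance, and whether exchanging cyano, carbamoyl, hydrogen, nitro or methanesulfonamido changes it at all.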